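Aryl Versus Cycloalkyl Groups on a Ring Amine Nitrogen

A few compounds are considered here, and "the series" means these few. Any claim that something is new, unique, unknown or untested is made for them only; others in the source may bear on it.

Compound 1 `Nc1scc(CN2CCN(c3ccccc3C(F)(F)F)CC2)c1C(=O)c1ccc(Cl)cc1`: 0%
Compound 2 `Nc1scc(CN2CCN(C3CCCC3)CC2)c1C(=O)c1ccc(Cl)cc1`: 3%

Of the compounds shown here, two sharing the same core have been measured in an assay on CHO cells for displacement of a labelled ligand from adenosine receptor A3 (Homo sapiens), read by scintillation counting, with a stated time of 120 min, tested at 10 uM; a higher number here means more inhibition at the concentration tested (going by the name of the read-out), a lower number less inhibition. Compound 1 gives 0% and compound 2 gives 3%. Compound 2 and compound 1 lie within the scatter of one another: a number 3 percentage points higher from compound 1 to compound 2 (within the scatter). Neither shows meaningful inhibition at the concentration tested.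

Compound 3 `Nc1scc(CN2CCN(c3ccccc3F)CC2)c1C(=O)c1ccc(Cl)cc1` has not yet been measured. It differs from compound 2 in one place: 2-fluorophenyl in place of cyclopentyl on an amine nitrogen in a ring. Within the data shown here, the only measured step that bears on this change is the one from compound 1 to compound 2, which replaced an aromatic ring on that same nitrogen with the cyclopentyl group, and it moved the number by a number 3 percentage points higher from compound 1 to compound 2 (within the scatter). Going back to an aromatic ring, now with fluorine instead of trifluoromethyl, therefore gives no ground to expect a step beyond the scatter in this assay. Compound 3 is expected to come out near the two figures already seen, with no change at the digits printed from compound 2 to compound 3 (within the scatter). The estimate for compound 3 is 3%, ranging from 0% to 15%.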

Compound 3, a percentage reported as inhibition, at one concentration (the size of the read-out at that concentration, not a potency): 0%
Compound 3: middle estimate off by 3 percentage points, on the high side; low and high end bracket the measured number.
By their numbers in this assay, from the lowest: compounds 1, 3 and 2 (each within the scatter of the next).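

Replacing cyclopentyl with 2-fluorophenyl on the amine nitrogen in the ring gives a number 3 percentage points lower from compound 2 to compound 3 (within the scatter) in this assay and so adds a second aromatic group at this position, this time carrying fluoro, to the picture: a five-membered non-aromatic ring of carbon and two differently substituted six-membered aromatic rings all leave the read-out within the scatter. Among these compounds, the substituent on the aromatic ring can now be compared directly for the first time, and fluoro in place of trifluoromethyl gives no change at the digits printed from compound 1 to compound 3 (within the scatter) in the same assay, so this change on the aromatic carbon also has no visible effect on the number. Nothing available explains why these three compounds read alike.

Since none of the three shows meaningful inhibition at the concentration tested, these numbers cannot tell whether the group on this nitrogen has any bearing on displacement of the labelled ligand or whether the shared core alone sets the outcome. On these data alone, it remains open whether a carboxylic acid, a primary amine or a longer chain ending in a hydroxyl group at this position would move the number in this assay beyond the scatter.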